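Swapping the Benzyl Group in a Cytotoxicity Series

The source may report more compounds than this note shows. Statements on the series, on what has been measured and on what is new or still open speak of the compounds shown alone.

Of the compounds shown here, two have been tested in an ADME assay on HaCaT cells (Homo sapiens) for cytotoxicity, read by MTT assay, with a stated time of 72 h; on this read-out higher numbers stand for weaker inhibition and lower numbers for stronger inhibition. Compound 1 `Cc1cccc(CSc2cc(Cl)c(C)cc2S(=O)(=O)/N=C(\N)n2nccc2-c2ccccc2)c1` gives 10000 nM in this assay, which is the lower of the two numbers, and so stands as the stronger inhibitor of cell growth among the pair. Compound 2 `Cc1cc(-c2ccccc2)n(/C(N)=N/S(=O)(=O)c2cc(C)c(Cl)cc2SCc2cccc(C(F)(F)F)c2)n1` gives 40000 nM in this assay, a number beyond the usual scatter away from that of compound 1; compound 2 differs from compound 1 in more than one place, so its gap cannot be tied to a single change.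

Compound 3 `Cc1cc(S(=O)(=O)/N=C(\N)n2nccc2-c2ccccc2)c(SCc2ccc(C(F)(F)F)cc2)cc1Cl` has not yet been measured. It differs from compound 1 in one place only: 4-(trifluoromethyl)phenyl in place of 3-methylphenyl on a saturated chain carbon bound to a sulfur. For the measured compounds named here, no measured pair shows exactly this change, so the size of the step is uncertain. Going by the values given here, the only guide is compound 2, which carries a trifluoromethyl-bearing benzyl group and gives 40000 nM in this assay, a weaker result than compound 1.

Compound 3 is therefore expected to be a somewhat weaker inhibitor than compound 1, by a step of about a 2.0-fold higher number from compound 1 to compound 3 (0.30 log units; within the scatter). The estimate for compound 3 in this assay is 20000 nM, with a plausible range from 7000 nM to 60000 nM.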

Compound 3, half-maximal inhibitory concentration: 19000 nM
Estimate against measurement, compound 3: 1.1-fold (0.02 log units) above; measured number inside the range.
By their numbers in this assay, from the lowest: compounds 1 and 3 (each within the scatter of the next); then compound 2.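

In this assay, putting 4-(trifluoromethyl)phenyl in place of 3-methylphenyl on a saturated chain carbon bound to a sulfur gives a 1.9-fold higher number from compound 1 to compound 3 (0.28 log units; within the scatter), and a step of this size lies within the usual scatter of repeated measurements. For the compounds shown here, this is the first direct one-place reading at this position, and it shows that the 3-methylbenzyl group can give way to the 4-(trifluoromethyl)benzyl group, which has more heavy atoms, with no difference that this read-out can separate from noise. Nothing available on these compounds explains why the number holds across this swap.

The compounds shown leave open whether any group at this position would produce a step beyond the scatter, for example a benzyl group carrying a carboxylic acid or an amine, or a longer chain on the sulfur. The swap also changes both the group itself and where it sits on the ring, and these two changes stay unseparated here.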